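Notes on a fatty acid receptor agonist series

A few compounds are considered here, and "the series" means these few. Any claim that something is new, unique, unknown or untested is made for them only; others in the source may bear on it.

Measured so far:
compound 1, `CC(C)C(C(=O)Nc1nc(-c2cccnc2)cs1)c1ccc(Cl)cc1`: < 30%
compound 2, `CSc1cnc(NC(=O)[C@H](c2ccc(Cl)cc2)C(C)(C)C)s1`: 109%

Among the compounds with values here, in a functional assay on CHO cells for agonist activity at Free fatty acid receptor 2 (Homo sapiens), read by cAMP accumulation (a lower number here means a smaller maximal response, a higher number a larger maximal response), compound 2 gives 109% and holds the only number in the set. For compound 1 the result is a limit of the assay, < 30%. Within the data shown here, since the limit of < 30% in this assay, at which 1 of the 2 values shown sits, is the only other point, compound 2 stands alone on the numeric scale and no step between two measured compounds can be drawn.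

Compound 3, `CC(C)(C)[C@H](C(=O)Nc1ncc(C(O)(C(F)(F)F)C(F)(F)F)s1)c1ccc(Cl)cc1`, is not yet measured. Relative to compound 2 the change is 2,2,2-trifluoro-1-hydroxy-1-(trifluoromethyl)ethyl in place of methylsulfanyl on an aromatic carbon. The methylsulfanyl group leaves and the 2,2,2-trifluoro-1-hydroxy-1-(trifluoromethyl)ethyl group enters on the same aromatic carbon of the five-membered aromatic ring with 1 nitrogen and 1 sulfur.

Among the measured compounds shown here, with no measured step to lean on, the direction is open. The expected step in this assay is a moderate fall, estimated as a number 29 percentage points lower from compound 2 to compound 3 (beyond the scatter), beyond the usual scatter but short of the limit. Compound 3 is expected at 80% in this assay, with a range from 30% to 115%.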

Compound 3, largest response reached (reported as efficacy), in percent of the reference or control that the assay uses: 113%
Estimate against measurement, compound 3: 33 percentage points below; low and high end bracket the measured number.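

The aromatic carbon next to the ring sulfur now has its first measured step in this assay: 2,2,2-trifluoro-1-hydroxy-1-(trifluoromethyl)ethyl in place of methylsulfanyl gives a number 4 percentage points higher from compound 2 to compound 3 (within the scatter), so the maximal response does not separate the two groups. This position therefore accepts a swap from a group of 2 heavy atoms with 0 hydrogen-bond donors to one of 10 heavy atoms with 1 hydrogen-bond donor, with no loss of response that can be read in this series. Nothing measured here bears on a cause for this result.

From the compounds shown here alone, whether a carboxylic acid or a dimethylamino group on this same aromatic carbon would give a comparable maximal response stays open, and a read-out of maximal response alone says nothing about how compound 2 and compound 3 compare in potency. Compound 1 stands at < 30%, a limit of the assay, and it differs from the other compounds in more than one place, so steps to it cannot be read.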